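Phosphate ester chain variation on the shared cytidine monophosphate core

The source may hold more compounds than are shown below. What is called first, only, known or untested is meant among the compounds shown, and "the series" means these compounds.

Measured compounds in this series:
compound 1, `CCOP(=O)(O)OC[C@H]1O[C@@H](n2ccc(N)nc2=O)[C@@H](O)[C@@H]1O`, 4 uM in a functional assay on L1210 cells (Mus musculus) for inhibition; on this read-out lower numbers stand for stronger inhibition and higher numbers for weaker inhibition;
compound 2, `CCCCOP(=O)(O)OC[C@H]1O[C@@H](n2ccc(N)nc2=O)[C@@H](O)[C@@H]1O`, 7.5 uM;
compound 3, `CCCCCCCCOP(=O)(O)OC[C@H]1O[C@@H](n2ccc(N)nc2=O)[C@@H](O)[C@@H]1O`, 11 uM.

Compound 3 holds the highest number of the three. Its nearest neighbour is compound 2, with a 1.5-fold higher number from compound 2 to compound 3 (0.17 log units; within the scatter); the step to compound 1 is larger, a 2.8-fold higher number from compound 1 to compound 3 (0.44 log units; beyond the scatter). Among the compounds with values here, both steps run the same way: the longer the chain on the phosphate oxygen, the higher the number, but the gaps are small and only the step from compound 1 reaches beyond the scatter.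

Compound 4, `Nc1ccn([C@@H]2O[C@H](COP(=O)(O)OCC(O)CO)[C@@H](O)[C@@H]2O)c(=O)n1`, is not yet measured. Relative to compound 3 the change is 1,2-dihydroxyethyl in place of heptyl on a saturated chain carbon bound to an oxygen on an unsaturated carbon. Within the data shown here, no measured step matches this change. Among the measured compounds shown here, the steps that bear on it are those shortening the chain, compound 3 to compound 1 and compound 3 to compound 2, which point to somewhat lower numbers for a shorter ester group; the two hydroxyl groups entering have no precedent here. The expected step is therefore estimated as a 2.2-fold lower number from compound 3 to compound 4 (0.34 log units; beyond the scatter). Compound 4 is estimated at 5 uM, with a range from 2 uM to 15 uM.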

Compound 4, concentration for 50% inhibition: 0.65 uM
Estimate against measurement, compound 4: 7.7-fold (0.89 log units) above, and the stated range ends above it.
By their numbers in this assay, from the lowest: compound 4; then compounds 1, 2 and 3 (each within the scatter of the next, the first and the last beyond it).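

At this position the group on the phosphate oxygen matters far more than the alkyl series suggested: with 2,3-dihydroxypropyl in place of the alkyl chains, this assay gives a 17-fold lower number from compound 3 to compound 4 (1.23 log units; beyond the scatter) and a 12-fold lower number from compound 2 to compound 4 (1.06 log units; beyond the scatter) and a 6.2-fold lower number from compound 1 to compound 4 (0.79 log units; beyond the scatter) as the three steps, all beyond the scatter. Compound 4 therefore holds the lowest number of the series, and it breaks the trend of the plain chains, since its chain is not simply a further point on the line running from octyl down to ethyl. Nothing given here accounts for the size of this change.

From the compounds shown here alone, compound 4 changes chain length and adds two hydroxyl groups in one move, so the share of each stays open. Also open, going by these compounds, is how a propyl chain bearing a single hydroxyl group, or an amine or carboxylic acid in place of the hydroxyl groups, would read.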